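Sulfonyl aryl substituent changes: estimate for compound 4

This account rests on a few compounds, and the source may have more. Where it says the series, first, only, none or still open, it means among the compounds named here.

Compound 1 `O=C(c1ccc(OCCCN2CC[C@H](NS(=O)(=O)c3ccc(Br)cc3)C2)cc1)C1CC1`, compound 2 `O=C(c1ccc(OCCCN2CC[C@H](NS(=O)(=O)c3cccc(Cl)c3)C2)cc1)C1CC1` and compound 3 `O=C(c1ccc(OCCCN2CC[C@H](NS(=O)(=O)c3ccc(Cl)cc3)C2)cc1)C1CC1` share one core and differ only in the aryl group on the sulfonyl sulfur. In an assay on isolated protein for binding affinity to histamine H2 receptor (Homo sapiens) (on this read-out lower numbers stand for stronger inhibition and higher numbers for weaker inhibition), compound 1 gives 290 nM, compound 2 gives 700 nM and compound 3 gives 290 nM. Exchanging one halogen for another gives no change at the digits printed from compound 1 to compound 3 (within the scatter), whereas moving the chlorine around the ring gives a 2.4-fold higher number from compound 1 to compound 2 (0.38 log units; beyond the scatter) and a 2.4-fold lower number from compound 2 to compound 3 (0.38 log units; beyond the scatter). Compound 3 thus stands level with compound 1, together the lowest of the three numbers, with compound 2 furthest away.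

Compound 4 `CCc1ccc(S(=O)(=O)N[C@H]2CCN(CCCOc3ccc(C(=O)C4CC4)cc3)C2)cc1` differs from compound 3 by ethyl in place of chloro on an aromatic carbon. Among the compounds with values here, no measured step exchanges a halogen for an alkyl group at this place. Within the data shown here, the only step at this place, no change at the digits printed from compound 1 to compound 3 (within the scatter), stayed within the scatter, and the position shifts were modest. A small change, if any, is therefore expected in this assay, with no clear direction. Compound 4 is expected to give 350 nM, in the range 150 nM to 900 nM. This estimate corresponds to an expected step of a 1.2-fold higher number from compound 3 to compound 4 (0.08 log units; within the scatter).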

Compound 4, inhibition constant: 330 nM
For compound 4 the middle estimate is 1.1-fold (0.03 log units) above the measured one; the range from low to high includes it.
By their numbers in this assay, from the lowest: compounds 1, 3 and 4 (each within the scatter of the next); then compound 2.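

In this assay, ethyl in place of chloro gives a 1.1-fold higher number from compound 3 to compound 4 (0.06 log units; within the scatter) and ethyl in place of bromo gives a 1.1-fold higher number from compound 1 to compound 4 (0.06 log units; within the scatter), so an alkyl group at this place, para to a large group, stays level with both halogens. The flat step seen earlier is therefore not confined to exchanging one halogen for another, and it holds with two heavy atoms entering where one leaves. The change from 3-chlorophenyl to 4-ethylphenyl gives a 2.1-fold lower number from compound 2 to compound 4 (0.33 log units; beyond the scatter), which alters both the substituent and its place, so this step alone does not separate the two changes.

Going by these compounds, whether an amine, a carboxylic acid or a longer alkyl chain at this place would also leave the number level remains open. Also open, on these data alone, is whether the gap separating 3-chlorophenyl extends to substituents other than chloro. The data shown offer nothing that explains these numbers.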